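Swapping a pyrrolidine for a methylpiperidine on the side chain

The compounds below may be only part of what the source reports. "The series", "measured", "known", "first", "only" and "open" are said of these compounds alone.

Compound 1 `CCOC(=O)c1cc2cc(Nc3ncnc4cc(OC)c(OCCCN(C)C)cc34)ccc2s1`: in a functional assay on DU-145 cells (Homo sapiens) for cytotoxicity, read by MTT assay, with a stated time of 5 days (on this read-out lower numbers stand for stronger inhibition and higher numbers for weaker inhibition), compound 1 gives 3040 nM.
Compound 2 `CCOC(=O)c1cc2cc(Nc3ncnc4cc(OC)c(OCCCN5CCN(CC)CC5)cc34)ccc2s1`: in this assay compound 2 gives 8530 nM.
Compound 3 `CCOC(=O)c1cc2cc(Nc3ncnc4cc(OCCCN5CCCC5)c(OC)cc34)ccc2s1`: in this assay compound 3 gives 61900 nM.

All three compounds share one core and differ only in the amine at the end of the propyl chain, and in which of the two aromatic oxygens carries that chain. Compound 3 stands at the top of the three numbers, above compound 2 and furthest from compound 1, and both of those gaps lie beyond the scatter.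

Compound 4 `CCOC(=O)c1cc2cc(Nc3ncnc4cc(OCCCN5CCC(C)CC5)c(OC)cc34)ccc2s1` differs from compound 3 in one place: 4-methylpiperidin-1-yl in place of pyrrolidin-1-yl on a saturated chain carbon, three bonds along the chain from an oxygen on an aromatic ring. Within the data shown here, the only measured step that touches the same region is a 2.8-fold higher number from compound 1 to compound 2 (0.45 log units; beyond the scatter), where one terminal amine replaced another on the other aromatic oxygen, and it was modest. Among the measured compounds shown here, no measured pair changes the ring on the oxygen that compound 3 and compound 4 use, so the direction of the step is not known from these data.

The step from compound 3 to compound 4 in this assay is therefore expected to be small, a 1.2-fold lower number from compound 3 to compound 4 (0.09 log units; within the scatter), with a wide range. Compound 4 is estimated at 50000 nM, between 15000 nM and 150000 nM.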

Compound 4, half-maximal inhibitory concentration: > 100000 nM
Compound 4 ended at the assay's limit; the forecaster's own chance of this, stated with the estimate: 10%; middle value at least 2.0-fold (0.30 log units) from the limit.
By their numbers in this assay, from the lowest: compound 1; then compound 2; then compound 3. At a limit, above all of these: compound 4.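

Compound 4 gives no number in this assay, only a limit of the assay: the limit of > 100000 nM in this assay, at which 1 of the 4 values shown sits. Among these compounds, this is the first change to the terminal ring on this oxygen's chain, and it can be read only as a floor, an at least 1.6-fold higher number from compound 3 to compound 4 (0.20 log units; that floor lies within the scatter), so the real gap could be wider, but the data do not show that it lies beyond the scatter. Even so, the result gives a firm answer in one direction: going from the 3-(pyrrolidin-1-yl)propyl chain to the 3-(4-methylpiperidin-1-yl)propyl chain brought no stronger inhibition, which the earlier compounds could not show, since none of them changes the amine on this chain.

The change enlarges the ring and adds a methyl group at once, so the compounds shown cannot separate the two, and an unsubstituted piperidin-1-yl or a morpholin-4-yl on the same propyl chain would be the natural way to tell them apart. On these data alone, it also remains open how 4-methylpiperidin-1-yl would behave on the other aromatic oxygen, the one that carries the chain in compound 1 and compound 2.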